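This account rests on a few compounds, and the source may have more. Where it says the series, first, only, none or still open, it means among the compounds named here.

Measured so far:
- compound 1, `CNC(=O)N1CCCc2ccc(NC(=O)c3cccc(-c4ccn(C(C)=O)n4)c3)cc21`: 27.6%
- compound 2, `CNC(=O)N1CCCc2ccc(NC(=O)c3cccc(-c4cc[nH]n4)c3)cc21`: 27.3%

In a functional assay on MV4-11 cells (Homo sapiens) for antiproliferative activity, with a stated time of 6 days, tested at 1.56 uM (a lower number here means a weaker effect, a higher number a stronger effect of the compound at the concentration tested), compound 2 has the lowest of the two numbers, and its nearest neighbour is compound 1, which lies within the scatter of it. Going by the values given here, the one step measured so far, a number 0.3 percentage points lower from compound 1 to compound 2 (within the scatter), shows that swapping hydrogen for acetyl on the aromatic nitrogen of the pyrazole did not move this assay beyond the scatter.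

Compound 3, `CNC(=O)N1CCCc2ccc(NC(=O)c3cccc(-c4cnn(S(C)(=O)=O)c4)c3)cc21`, is the next compound to be measured in this assay. It differs from compound 2 as follows: 1-(methylsulfonyl)-1H-pyrazol-4-yl in place of 1H-pyrazol-3-yl on an aromatic carbon

Among the compounds with values here, the only step that bears on this change is the one from compound 1 to compound 2, since it also concerns a group on the aromatic nitrogen of the pyrazole; that step was within the scatter. Within the data shown here, the shift of the attachment point from 1H-pyrazol-3-yl to 1-(methylsulfonyl)-1H-pyrazol-4-yl has no measured counterpart, so the expectation rests on the one step alone. On that basis, the expected step of a number 0.7 percentage points higher from compound 2 to compound 3 (within the scatter) is small, with no direction beyond the scatter. Compound 3 is thus estimated at 28% in this assay, within a range from 8% to 50%.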

Compound 3, a percentage reported as inhibition, at one concentration (the size of the read-out at that concentration, not a potency): 1.6%
The estimate for compound 3 lay 26.4 percentage points above the measured number; the whole stated range lies above it.
By their numbers in this assay, from the lowest: compound 3; then compounds 2 and 1 (each within the scatter of the next).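

In this assay the group on the aromatic carbon, meta to a large group, is not indifferent: the change to 1-(methylsulfonyl)-1H-pyrazol-4-yl gives a number 25.7 percentage points lower from compound 2 to compound 3 (beyond the scatter) and a number 26 percentage points lower from compound 1 to compound 3 (beyond the scatter) at the single concentration tested. Acetyl and hydrogen on the pyrazole nitrogen had not separated compounds 1 and 2, so this is the first change in the series to move the read-out beyond the scatter, though it alters both the attachment point and the nitrogen substituent in one step. Nothing available accounts for the drop, and the cause remains unassigned.

The compounds shown do not separate the two parts of the change: 1H-pyrazol-4-yl and 1-(methylsulfonyl)-1H-pyrazol-3-yl would each isolate one of them. Also open, as far as these compounds go, is whether the low read-out extends to other nitrogen substituents on the 4-linked pyrazole, such as methyl or a longer chain carrying an amine, or whether it is confined to methylsulfonyl.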